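The compounds below may be only part of what the source reports. "The series", "measured", "known", "first", "only" and "open" are said of these compounds alone.

The measured compounds:
compound 1, `Cc1ccc(-c2csc(NC(=O)COc3ccccc3C)n2)cc1`, gives 50100 nM in a functional assay on A549 cells (Homo sapiens) for cytotoxicity, read by trypan blue exclusion, with a stated time of 48 h; a lower number here means a stronger inhibitor, a higher number a weaker inhibitor;
compound 2, `Cc1ccc(-c2csc(NC(=O)COc3ccc(F)cc3F)n2)cc1`, gives 13200 nM in this assay;
compound 3, `Cc1ccccc1OCC(=O)Nc1nc(-c2ccc(Cl)cc2)cs1`, gives 64800 nM in this assay.

These three share a core, and two of them differ only in the aryl group on the ether oxygen. Compound 2 differs from compound 1 by 2,4-difluorophenyl in place of 2-methylphenyl on an oxygen on a saturated carbon, and that change gave a 3.8-fold lower number from compound 1 to compound 2 (0.58 log units; beyond the scatter). Compound 3 differs from compound 1 in the core by chloro in place of methyl on an aromatic carbon, and that difference gave a 1.3-fold higher number from compound 1 to compound 3 (0.11 log units; within the scatter), so the two cores behave alike as far as these numbers show.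

Compound 4, `O=C(COc1ccc(F)cc1F)Nc1nc(-c2ccc(Cl)cc2)cs1`, has not yet been measured in this assay. It differs from compound 3 by 2,4-difluorophenyl in place of 2-methylphenyl on an oxygen on a saturated carbon. Going by the values given here, the surroundings of the change, an oxygen on a saturated carbon whose other neighbour is a saturated chain carbon, are the same word for word in both pairs, so this is the same change as the one from compound 1 to compound 2, now made on the core of compound 3. Among the compounds with values here, with only one earlier example of the change, the expectation rests on that single step and on the value of compound 3, 64800 nM. For compound 4 the expected step is a 3.8-fold lower number from compound 3 to compound 4 (0.58 log units; beyond the scatter), close to the earlier one. Compound 4 is therefore estimated at 17000 nM, with a likely range from 7000 nM to 40000 nM.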

Compound 4, half-maximal inhibitory concentration: 26300 nM
For compound 4 the middle estimate is 1.5-fold (0.19 log units) below the measured one; the measured number falls inside the stated range.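

On the core of compound 3, putting 2,4-difluorophenyl in place of 2-methylphenyl again lowers the number in this assay, giving a 2.5-fold lower number from compound 3 to compound 4 (0.39 log units; beyond the scatter), and the two examples of this change agree: the same change on two cores in this assay, a 3.8-fold lower number (0.58 log units; beyond the scatter) from compound 1 to compound 2 and a 2.5-fold lower number (0.39 log units; beyond the scatter) from compound 3 to compound 4, 1.5-fold (0.19 log units) apart, within the scatter of two such steps

The other change, chloro in place of methyl on an aromatic carbon, gives a 2.0-fold higher number from compound 2 to compound 4 (0.30 log units; within the scatter), and it too reads the same in both settings: the same change on two cores in this assay, a 1.3-fold higher number (0.11 log units; within the scatter) from compound 1 to compound 3 and a 2.0-fold higher number (0.30 log units; within the scatter) from compound 2 to compound 4, 1.5-fold (0.19 log units) apart, within the scatter of two such steps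

Together these four compounds show that, in this small set, each change has about the same effect whichever form of the other part it is made on, but they do not show that this would hold on any other core, in any other assay, or why the number moves at all.

The compounds shown leave open whether both fluorines are needed, since no phenyl ring carrying a single fluoro group appears here. They also leave open how the number would respond to a nitrile or an amine on that ring, to a longer chain in place of the saturated carbon, or to a methoxy group in place of the chloro or methyl.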